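This account rests on a few compounds, and the source may have more. Where it says the series, first, only, none or still open, it means among the compounds named here.

Measured in an assay on isolated protein for inhibition of Indoleamine 2,3-dioxygenase 1 (Homo sapiens); a lower number here means a stronger inhibitor, a higher number a weaker inhibitor:

Compound 1 `O=C1Nc2ccccc2/C1=N/Nc1cccc(Cl)c1` gives 1510 nM
Compound 2 `O=C1Nc2ccccc2/C1=N/Nc1ccccc1C(F)(F)F` gives 1580 nM

Both compounds share the same core and differ only in the group carried on the outer benzene ring. Compound 1 has the smaller of the two numbers, but the gap to compound 2 lies within the usual scatter of repeated measurements, so the two cannot be told apart and neither can be called the stronger inhibitor. On these two numbers compound 1 is simply one of a closely matched pair.

Compound 3 `O=C1Nc2ccccc2/C1=N/Nc1cccc([N+](=O)[O-])c1` has not been measured yet. It differs from compound 1 in one place: nitro in place of chloro on an aromatic carbon — in words, nitro in place of chloro on an aromatic carbon, meta to a large group. For the measured compounds named here, no pair of measured compounds shows this kind of exchange, so there is no measured step to lean on. The expected step is a 1.2-fold higher number from compound 1 to compound 3 (0.08 log units; within the scatter), that is, no shift clearly beyond the scatter in either direction. Compound 3 is therefore estimated at about 1800 nM, with a range from 600 nM to 5500 nM.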

Compound 3, half-maximal inhibitory concentration: 3740 nM
Beside the measured number, compound 3's estimate is 2.1-fold (0.32 log units) below it; the range from low to high includes it.
By their numbers in this assay, from the lowest: compounds 1 and 2 (each within the scatter of the next); then compound 3.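

In this assay, for the compounds shown here, nitro in place of chloro on this aromatic carbon, meta to a large group, gives a 2.5-fold higher number from compound 1 to compound 3 (0.39 log units; beyond the scatter), the first measured step at this position and one towards a weaker inhibitor. The result shows that the group held here can shift the number beyond the usual scatter, so this place on the outer ring is not indifferent to an exchange, although the step is modest and rests on a single pair of compounds. Nothing among the data shown accounts for the shift, so the step stands as an observation and not as an explanation.

Open, from the compounds shown here alone, is whether the higher number belongs to nitro in particular or would also appear with other groups on the same carbon, such as an amine, a methoxy group or a nitrile, each of which would give a further step to set beside this one. Also open, going by these compounds, is whether the same exchange of chloro for nitro at other places on the outer ring would give a step of similar size, or one in the opposite direction.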